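From compound 1 to compound 3: an added ethoxy group

The compounds below may be only part of what the source reports. "The series", "measured", "known", "first", "only" and "open" are said of these compounds alone.

Compound 1 (`Cc1cc(O)c(C(=O)/C=C/c2ccccc2)c(=O)o1`) offers no exact figure. In a functional assay on HCT-116 cells (Homo sapiens) for cytotoxicity, read by MTT assay (on this read-out lower numbers stand for stronger inhibition and higher numbers for weaker inhibition), compound 1 gives > 100000 nM as a limit of the assay and not a number. Compound 2 (`Cc1cc(O)c(C(=O)/C=C/c2ccco2)c(=O)o1`) carries furan-2-yl in place of phenyl. In this assay compound 2 gives > 100000 nM as a limit as well. Going by the values given here, the only measured step is a step that the two limits leave unreadable from compound 1 to compound 2 and the evidence, (the limit of > 100000 nM in this assay, at which 2 of the 2 values shown sit), gives it no size. Compound 3 (`CCOc1ccc(/C=C/C(=O)c2c(O)cc(C)oc2=O)cc1`) differs from compound 1 by ethoxy in place of hydrogen on an aromatic carbon in the same region of the molecule. Resting on a step that the two limits leave unreadable from compound 1 to compound 2 alone, no step beyond the scatter is expected in this assay and compound 3 is expected to stay weak, quite possibly at the limit again. The expected change is a number no higher from compound 1 to compound 3 (the limit leaves the size open) as an estimate only. For compound 3 the estimated value is 100000 nM with an expected range from 40000 nM to 200000 nM.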

Compound 3, half-maximal inhibitory concentration: > 100000 nM
Compound 3 ended at the assay's limit; the forecaster's own chance of this, stated with the estimate: 70%; the middle value lies on the limit itself.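

Compound 1 and compound 3 both give only a limit in this assay, so no step between them can be read: the limit of > 100000 nM in this assay, at which 3 of the 3 values shown sit.

The compounds shown leave open what exact values compound 1, compound 2 and compound 3 would have in this assay, and whether ethoxy or furan-2-yl changes them at all.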